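Two indole acetyl compounds and a styryl analogue

The source may hold more compounds than are shown below. What is called first, only, known or untested is meant among the compounds shown, and "the series" means these compounds.

Measured so far:
Compound 1, `CC(=O)c1cc(-c2ccc(F)cc2)cc2cc(-c3ccccc3)[nH]c12` — 82.7%
Compound 2, `COc1ccc(-c2cc(C(C)=O)c3[nH]c(-c4ccccc4)cc3c2)cc1` — 88.8%

In a functional assay on MCF7 cells (Homo sapiens) for cytotoxicity, read by MTT assay, with a stated time of 2 days, tested at 1 uM (a higher number here means a weaker effect of the compound at the concentration tested, a lower number a stronger effect), compound 1 gives 82.7% and compound 2 gives 88.8%. For the measured compounds named here, the one step between measured compounds, a number 6.1 percentage points higher from compound 1 to compound 2 (within the scatter), is within the scatter, so compound 2 stands where compound 1 stands, and neither can be called stronger or weaker than the other.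

Compound 3, `CC(=O)c1cc(/C=C/c2ccccc2)cc2cc(-c3ccccc3)[nH]c12`, has not been measured. It differs from compound 2 in one place: 2-phenylethenyl in place of 4-methoxyphenyl on an aromatic carbon. Going by the values given here, no measured step concerns this change; the only step known, from fluoro to methoxy, did not move the number beyond the scatter, and it says nothing about a 2-phenylethenyl group. For compound 3 the expected step is therefore a number 3.8 percentage points lower from compound 2 to compound 3 (within the scatter), none beyond the scatter. Compound 3 is estimated at 85%, expected between 65% and 100% in this assay.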

Compound 3, a percentage reported as activity, at one concentration (the size of the read-out at that concentration, not a potency): 93.4%
Beside the measured number, compound 3's estimate is 8.4 percentage points below it; the range from low to high includes it.
By their numbers in this assay, from the lowest: compounds 1, 2 and 3 (each within the scatter of the next, the first and the last beyond it).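

In this assay, for the compounds shown here, replacing 4-fluorophenyl with 2-phenylethenyl gives the first step at this position that lies beyond the scatter, with a number 10.7 percentage points higher from compound 1 to compound 3 (beyond the scatter) and so a modest weakening of the effect at the concentration tested. Replacing 4-methoxyphenyl with the same group does not separate the two compounds, the step being a number 4.6 percentage points higher from compound 2 to compound 3 (within the scatter) and so no clear change, which means the single separation rests on the 4-fluorophenyl comparison alone. Nothing available explains this difference.

The compounds shown leave open whether an amine or a carboxylic acid on the aromatic ring at this position, or a longer chain in place of the 2-phenylethenyl group, would give a clearly stronger effect. From the compounds shown here alone, the acetyl group and the phenyl group on the shared core stay the same throughout, so the effect of changing either remains unknown.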